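Trimethoxyphenyl amides on ONS-76 cells: working notes

The source may report more compounds than this note shows. Statements on the series, on what has been measured and on what is new or still open speak of the compounds shown alone.

Compound 1 `COc1cc(N(C)C(=O)N(C)c2cccc(F)c2)cc(OC)c1OC` opens the series. In a functional assay on ONS-76 cells (Homo sapiens) for cytotoxicity, read by MTT assay, with a stated time of 72 h (on this read-out lower numbers stand for stronger inhibition and higher numbers for weaker inhibition), compound 1 reaches only the limit of the assay, >= 125000 nM. Compound 2 `COc1cc(N(C)C(=O)c2cccc(F)c2)cc(OC)c1OC` is the second measured member. In this assay compound 2 likewise gives only a limit, >= 125000 nM. Both measured values thus sit at the same place: the limit of >= 125000 nM in this assay, at which 2 of the 2 values shown sit. Compound 3 `COc1ccc(C(=O)N(C)c2cc(OC)c(OC)c(OC)c2)cc1` differs from compound 2 by 4-methoxyphenyl in place of 3-fluorophenyl on a carbonyl carbon. Among the measured compounds shown here, no step between measured compounds is available, so the expectation for compound 3 rests on compound 2 alone and is a step that the limit leaves unreadable from compound 2 to compound 3, nothing beyond the scatter. Compound 3 is estimated at 150000 nM, within 40000 nM to 500000 nM, most likely reported again as a limit.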

Compound 3, half-maximal inhibitory concentration: >= 125000 nM
Compound 3: a limit, no number; the forecaster's own chance of this, stated with the estimate: 80%; the middle value lies beyond the limit too.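

No step can be read between compound 2 and compound 3, as both stand only at a limit in this assay: the limit of >= 125000 nM in this assay, at which 3 of the 3 values shown sit. The compounds shown leave open which change to the core, if any, would give a measurable value.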